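The source may hold more compounds than are shown below. What is called first, only, known or untested is meant among the compounds shown, and "the series" means these compounds.

Compound 1 `C[C@@H](Nc1c(C(=O)NCc2ccc(F)cc2)nc(Br)c2cccnc12)c1ccccc1`: > 20000 nM, a limit
Compound 2 `NCCCNc1c(C(=O)NCc2ccc(F)cc2)nc(Br)c2cccnc12`: > 20000 nM, a limit

In a functional assay on HCT-116 cells (Homo sapiens) for cytotoxicity, read by MTT assay, with a stated time of 72 h (on this read-out lower numbers stand for stronger inhibition and higher numbers for weaker inhibition), compound 2 reads > 20000 nM, which is a limit of the assay and not a number. Compound 1 reads > 20000 nM, likewise a limit. Within the data shown here, the one measured step, a step that the two limits leave unreadable from compound 1 to compound 2, therefore has no readable size, and the record so far is the limit of > 20000 nM in this assay, at which 2 of the 2 values shown sit.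

Compound 3 `Nc1ccc(Nc2c(C(=O)NCc3ccc(F)cc3)nc(Br)c3cccnc23)cc1` carries 4-aminophenyl in place of 3-aminopropyl on a nitrogen on an aromatic ring. Among the measured compounds shown here, no measured step gives a size for this change, so the expectation rests only on (the limit of > 20000 nM in this assay, at which 2 of the 2 values shown sit). The step of an at least 1.1-fold lower number from compound 2 to compound 3 (0.04 log units; that floor lies within the scatter) is expected to be small at most, towards stronger inhibition if it can be read at all, and a further limit in this assay is quite likely. Compound 3 is estimated at 18000 nM, with an expected range from 5000 nM to 40000 nM.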

Compound 3, half-maximal inhibitory concentration: 10000 nM
Beside the measured number, compound 3's estimate is 1.8-fold (0.26 log units) above it, within the range that was stated.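

In this assay, compound 3 is the only one of the three shown that gives a number rather than a limit, so a value within the assay's range can be read with this group on a nitrogen on an aromatic ring. Replacing 3-aminopropyl with 4-aminophenyl gives an at least 2.0-fold lower number from compound 2 to compound 3 (0.30 log units; that floor lies within the scatter), and replacing 1-phenylethyl with 4-aminophenyl gives an at least 2.0-fold lower number from compound 1 to compound 3 (0.30 log units; that floor lies within the scatter). Each floor lies within the scatter, so neither step is shown to be a real gain, and the true sizes stay unknown, with most of the record still at the limit: the limit of > 20000 nM in this assay, at which 2 of the 3 values shown sit.

As far as these compounds go, it remains open whether the aromatic ring or its amine goes with the lower number, a question that a plain phenyl on the same nitrogen would address. From the compounds shown here alone, how a longer chain ending in an amine would compare also stays open.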